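The compounds below may be only part of what the source reports. "The series", "measured", "known", "first", "only" and "open" are said of these compounds alone.

Compound 1 `Oc1nc2nonc2nc1Nc1ccc(C(F)(F)F)cc1F` and compound 3 `Oc1nc2nonc2nc1Nc1ccc(OC(F)(F)F)cc1F` share a core and differ in one place: trifluoromethoxy in place of trifluoromethyl on an aromatic carbon. In an assay on mitochondria from L6 cells (Rattus norvegicus) for activation, with a stated time of 90 min (on this read-out lower numbers stand for an effect already at smaller amounts and higher numbers for an effect only at larger amounts of compound), compound 1 gives 2600 nM, and compound 3 gives 2300 nM, so that change made a 1.1-fold lower number from compound 1 to compound 3 (0.05 log units; within the scatter). Compound 2 `Oc1nc2nonc2nc1Nc1ccc(C(F)(F)F)c(F)c1` holds the same atoms as compound 1 joined differently; the difference between the two cores is not broken down here. In this assay compound 2 gives 11600 nM, the highest of the three numbers. Compound 4 `Oc1nc2nonc2nc1Nc1ccc(OC(F)(F)F)c(F)c1` relates to compound 2 in the same way: trifluoromethoxy in place of trifluoromethyl on an aromatic carbon. The place is not identical, meta to a fluoro group in the first pair and ortho to a fluoro group here, so this is the same kind of change rather than the same one. For compound 4 the expected step is a 1.1-fold lower number from compound 2 to compound 4 (0.04 log units; within the scatter), because the earlier change gave a 1.1-fold lower number from compound 1 to compound 3 (0.05 log units; within the scatter). Compound 4 is therefore estimated at 10500 nM, most likely between 4500 nM and 25000 nM.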

Compound 4, half-maximal effective concentration: 2900 nM
The estimate for compound 4 lay 3.6-fold (0.56 log units) above the measured number; the measured number lies below the stated range.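

Putting trifluoromethoxy in place of trifluoromethyl gave a 4.0-fold lower number from compound 2 to compound 4 (0.60 log units; beyond the scatter) in this assay. The size of this change therefore did not carry over from one core to the other: the same change on two cores in this assay, a 1.1-fold lower number (0.05 log units; within the scatter) from compound 1 to compound 3 and a 4.0-fold lower number (0.60 log units; beyond the scatter) from compound 2 to compound 4, 3.5-fold (0.55 log units) apart, beyond the scatter of two such steps

What this does not show is why the two steps differ, and two pairs cannot tell how large the step would be on a further core in this series. The compounds shown leave open how other groups would behave in the same place, such as a nitrile, an amine or a longer chain. They also leave open whether the gap between the two steps would persist in an assay of another kind.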